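A few compounds are considered here, and "the series" means these few. Any claim that something is new, unique, unknown or untested is made for them only; others in the source may bear on it.

In a functional assay on HL-60 cells (Homo sapiens) for cytotoxicity, read by MTT assay, with a stated time of 72 h (a lower number here means a stronger inhibitor, a higher number a weaker inhibitor), compound 1 (`COC(=O)c1sc2c(C)cccc2c1Nc1cc(OC)c(OC)c(OC)c1`) gives 4270 nM while compound 2 (`COC(=O)c1sc2cc(OC)ccc2c1Nc1cc(OC)c(OC)c(OC)c1`) gives 0.4 nM and so holds the lower of the two numbers, by a gap well beyond the scatter. These two compounds differ in more than one place, so their gap cannot be pinned on any single group. Compound 3 (`COC(=O)c1sc2cc(C)ccc2c1Nc1cc(OC)c(OC)c(OC)c1`) differs from compound 2 in one place, with methyl in place of methoxy on an aromatic carbon. Among the measured compounds shown here, no measured pair shows this change alone, which leaves the expectation loose. A weaker result is expected, because compound 2 at 0.4 nM already sits very low. The expected move is an estimated 20-fold higher number from compound 2 to compound 3 (1.30 log units; beyond the scatter) in the direction of a higher number, beyond the scatter. Compound 3 is estimated at 8 nM (expected range 1 nM to 100 nM) in this assay once tested.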

Compound 3, half-maximal inhibitory concentration: 20.5 nM
Compound 3: the middle estimate sits 2.6-fold (0.41 log units) below what was measured, and the stated range covers the measured number.
By their numbers in this assay, from the lowest: compound 2; then compound 3; then compound 1.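

Among the compounds shown here, compound 2 and compound 3 form the first pair here that differ in one place, so a single change can finally be read: in this assay, putting methyl in place of methoxy on this aromatic carbon gives a 51-fold higher number from compound 2 to compound 3 (1.71 log units; beyond the scatter). This position is far from indifferent, since the swap is small, from 2 heavy atoms to 1, yet the step is large and lies beyond the scatter. The swap removes an oxygen, and with it a hydrogen-bond acceptor, but one pair cannot say whether that oxygen is what matters.

On these data alone, whether a hydroxyl, an amine, a chlorine or a longer chain such as ethoxy on this carbon would sit nearer compound 2 or compound 3 remains open. Nothing measured here explains the size of the step.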